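The compounds below may be only part of what the source reports. "The series", "measured", "known", "first", "only" and "open" are said of these compounds alone.

Compound 1 `C=C(CC)C(=O)c1ccc(OCC(=O)Nc2ccc3c(C)cc(=O)oc3c2)c(Cl)c1Cl` gives 2800 nM. Compound 3 `C=C(CC)C(=O)c1ccc(OCC(=O)Nc2ccc(C(=O)NC(CCC(=O)OCC)C(=O)OCC)cc2)c(Cl)c1Cl` gives 2100 nM. Compound 2 `C=C(CC)C(=O)c1ccc(OCC(=O)NCC(=O)O)c(Cl)c1Cl` is reported only as a limit, > 25000 nM.

In a functional assay on CLL cells (Homo sapiens) for cytotoxicity, read by MTT assay, with a stated time of 48 h (on this read-out lower numbers stand for an effect already at smaller amounts and higher numbers for an effect only at larger amounts of compound), compound 1 and compound 3 sit within the usual scatter of each other, so no order between them can be claimed. Among the compounds with values here, compound 2 stands apart as the one value that is only a limit, (the limit of > 25000 nM in this assay, at which 1 of the 3 values shown sits). Compound 4 `C=C(CC)C(=O)c1ccc(OCC(=O)NCCCN2CCCC2=O)c(Cl)c1Cl` differs from compound 2 in one place: 2-(2-oxopyrrolidin-1-yl)ethyl in place of carboxy on a saturated chain carbon bound to an amide-type nitrogen. Within the data shown here, no measured pair shows this kind of change, so its size cannot be read from the data. Compound 4 is expected to come nearer to compound 1 and compound 3 than compound 2 did, with an estimated 8000 nM and a range from 2500 nM to 25000 nM. This expectation means a step of an at least 3.1-fold lower number from compound 2 to compound 4 (0.49 log units; beyond the scatter).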

Compound 4, half-maximal effective concentration: 13800 nM
Beside the measured number, compound 4's estimate is 1.7-fold (0.24 log units) below it; low and high end bracket the measured number.
By their numbers in this assay, from the lowest: compounds 3 and 1 (each within the scatter of the next); then compound 4. At a limit, above all of these: compound 2.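

Replacing carboxy with 2-(2-oxopyrrolidin-1-yl)ethyl on a saturated chain carbon bound to an amide-type nitrogen yields a measured number in this assay, where compound 4 gives 13800 nM. Compound 2 is only a limit: the limit of > 25000 nM in this assay, at which 1 of the 4 values shown sits. The change therefore reads as an at least 1.8-fold lower number from compound 2 to compound 4 (0.25 log units; that floor lies within the scatter), so its true size remains unfixed.

Going by these compounds, it remains open whether the five-membered ring matters or only the loss of carboxy. A simple amine or a longer chain ending in a carboxylic acid at this place could separate the two.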